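The source may hold more compounds than are shown below. What is called first, only, known or untested is meant among the compounds shown, and "the series" means these compounds.

Compound 3, `Cc1nc(S(C)(=O)=O)ccc1Oc1ncnc(OC2CCN(C(=O)SC3(C)CC3)CC2)c1F`, belongs to a series sharing one core, where the variation sits on a carbonyl carbon attached to an amide-type nitrogen in a ring. In a functional assay on isolated protein for inhibition of Glucose-dependent insulinotropic receptor (Rattus norvegicus), read by HTRF and cAMP accumulation (on this read-out lower numbers stand for smaller maximal responses and higher numbers for larger maximal responses), compound 3 gives 77%. Its companions are compound 1, `Cc1nc(S(C)(=O)=O)ccc1Oc1ncnc(OC2CCN(C(=O)OC(C)(C)C(F)(F)F)CC2)c1F`, which in this assay gives 79%, and compound 2, `Cc1nc(S(C)(=O)=O)ccc1Oc1ncnc(OC2CCN(C(=O)O[C@H](C)CF)CC2)c1F`, which in this assay gives 79%. The step of a number 2 percentage points lower from compound 1 to compound 3 (within the scatter) and the step of a number 2 percentage points lower from compound 2 to compound 3 (within the scatter) both stay within the scatter, as does no change at the digits printed from compound 1 to compound 2 (within the scatter), so compound 3 is not separated from either companion on these numbers.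

Compound 4, `Cc1nc(S(C)(=O)=O)ccc1Oc1ncnc(OC2CCN(C(=O)C(C)(F)F)CC2)c1F`, differs from compound 3 as follows: a group of 4 heavy atoms (2 carbon, 2 fluorine; no ring) in place of a group of 5 heavy atoms (4 carbon, 1 sulfur; one three-membered non-aromatic ring of carbon only), on a carbonyl carbon. All three measured steps alter the same carbonyl carbon and none moved this assay beyond the scatter, so this further exchange at that position is expected to leave the largest response essentially unchanged. Compound 4 is therefore estimated at 77% in this assay, with a range of 68% to 86%, an expected step of no change at the digits printed from compound 3 to compound 4 (within the scatter).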

Compound 4, largest response reached (reported as efficacy), in percent of the reference or control that the assay uses: 87%
The estimate for compound 4 lay 10 percentage points below the measured number; the measured number lies above the stated range.
By their numbers in this assay, from the lowest: compounds 3, 1, 2 and 4 (each within the scatter of the next).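

With 1,1-difluoroethyl, a group joined to the carbonyl carbon through carbon rather than through oxygen or sulfur, this assay reads a number 10 percentage points higher from compound 3 to compound 4 (within the scatter), a number 8 percentage points higher from compound 2 to compound 4 (within the scatter) and a number 8 percentage points higher from compound 1 to compound 4 (within the scatter). The series therefore now includes a change in the atom joined to this carbonyl carbon, and compound 4 is still not separated from any of the three other compounds on these numbers. Nothing available here accounts for the result.

The compounds shown leave open whether a dimethylamino group or a longer chain such as 1,1-difluoropropyl on this carbonyl carbon would also stay within the scatter. They also leave open whether the same holds with any other core, since all four compounds share one.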